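Chain terminus change on the shared core, compound 2 to 3

The source may hold more compounds than are shown below. What is called first, only, known or untested is meant among the compounds shown, and "the series" means these compounds.

Measured so far:
compound 1 `Cn1c(-c2ccccc2C(F)(F)F)nnc1C12CCC(CCS(C)(=O)=O)(CC1)CC2` — > 4000 nM
compound 2 `CCS(=O)(=O)CCCCC12CCC(c3nnc(-c4ccccc4C(F)(F)F)n3C)(CC1)CC2` — > 4000 nM

In an assay on CHO-K1 cells for inhibition of 11-beta-hydroxysteroid dehydrogenase type 2 (Homo sapiens), read by scintillation proximity assay (a higher number here means a weaker inhibitor, a lower number a stronger inhibitor), compound 1 gives > 4000 nM, which is a limit of the assay and not a number. In this assay compound 2 gives > 4000 nM, again a limit rather than a number. The single measured step, a step that the two limits leave unreadable from compound 1 to compound 2, is therefore unreadable: both values sit at the limit of > 4000 nM in this assay, at which 2 of the 2 values shown sit, and compound 2 cannot be placed relative to compound 1 on the numbers shown.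

Compound 3 `CC(F)CCCC12CCC(c3nnc(-c4ccccc4C(F)(F)F)n3C)(CC1)CC2` carries the change (1-fluoroethyl in place of (ethylsulfonyl)methyl on a saturated chain carbon, three bonds along the chain from a saturated ring carbon). Among the compounds with values here, no measured step bears on this change: the only step measured runs from compound 1 to compound 2 and has no readable size, and neither compound gives a number below the limit. No direction or size beyond the scatter can be derived for this assay from the data.

The expectation for compound 3 is that it again sits at or near the limit in this assay, with an estimate of 6000 nM and a range from 2000 nM to 20000 nM. The step that the limit leaves unreadable from compound 2 to compound 3 is expected to be essentially flat, with the value most likely reported as a limit once more.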

Compound 3, half-maximal inhibitory concentration: 1300 nM
For compound 3 the middle estimate is 4.6-fold (0.66 log units) above the measured one; the whole stated range lies above it.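

In this assay, within the data shown here, 1-fluoroethyl in place of (ethylsulfonyl)methyl, on a saturated chain carbon, three bonds along the chain from a saturated ring carbon, gives the first readable step: an at least 3.0-fold lower number from compound 2 to compound 3 (0.48 log units; beyond the scatter). The same chain end set against the shorter sulfonyl compound, as 2-fluoropropyl in place of methylsulfonyl, gives an at least 3.0-fold lower number from compound 1 to compound 3 (0.48 log units; beyond the scatter), which makes compound 3, at 1300 nM, the strongest inhibitor of the three and shows that this chain end can shift the read-out beyond the scatter. The full size of both steps remains unknown and the step between the two sulfonyl compounds cannot be read, since compound 1 and compound 2 each give a limit and not a number: the limit of > 4000 nM in this assay, at which 2 of the 3 values shown sit.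

The compounds shown do not separate the presence of the fluorine from the loss of the ethylsulfonyl group, a question that a plain ethyl or a hydroxyl-bearing ethyl group in place of 1-fluoroethyl would address. From the compounds shown here alone, how an amine or a carboxylic acid at the same chain carbon would read in this assay also remains open.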